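Swapping the amine on the acrylamide side chain of a quinazoline

The source may hold more compounds than are shown below. What is called first, only, known or untested is meant among the compounds shown, and "the series" means these compounds.

Measured compounds:
compound 1, `CCN(CC)C/C=C/C(=O)Nc1cc2c(N3CCCc4ccccc43)ncnc2cc1OC`, 6410 nM
compound 2, `COc1cc2ncnc(N3CCCc4ccccc43)c2cc1NC(=O)/C=C/CN1CCCC1`, 2230 nM
compound 3, `CCN(CC)C/C=C/C(=O)Nc1cc2c(N3CCCc4ccccc43)ncnc2cc1O[C@@H]1CCOC1`, 5650 nM

All three were tested in a functional assay on A549 cells (Homo sapiens) for antiproliferative activity, read by MTT assay, with a stated time of 72 h; on this read-out higher numbers stand for weaker inhibition and lower numbers for stronger inhibition. Compound 1 and compound 3 share the amine on the side chain and differ only in the group on the aromatic oxygen: oxolan-3-yl in place of methyl on an oxygen on an aromatic ring. That change gave a 1.1-fold lower number from compound 1 to compound 3 (0.05 log units; within the scatter), so the two compounds cannot be told apart on this read-out.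

Compound 2 differs from compound 1 in one place: pyrrolidin-1-yl in place of diethylamino on a saturated chain carbon bound to a double-bonded chain carbon. This step gave a 2.9-fold lower number from compound 1 to compound 2 (0.46 log units; beyond the scatter), a modest gain.

Compound 4, `O=C(/C=C/CN1CCCC1)Nc1cc2c(N3CCCc4ccccc43)ncnc2cc1O[C@@H]1CCOC1`, is not yet measured. It stands to compound 3 as compound 2 stands to compound 1: pyrrolidin-1-yl in place of diethylamino on a saturated chain carbon bound to a double-bonded chain carbon. The place of the change is the same in both pairs, so the change is the same; only the core differs, as told above. Because the step of a 2.9-fold lower number from compound 1 to compound 2 (0.46 log units; beyond the scatter) was modest and the cores barely differ in this assay, compound 4 is expected to show a similar step, a 2.8-fold lower number from compound 3 to compound 4 (0.45 log units; beyond the scatter). The estimate for compound 4 in this assay is 2000 nM, with a likely range from 1000 nM to 4500 nM.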

Compound 4, half-maximal inhibitory concentration: 6510 nM
Compound 4: the middle estimate sits 3.3-fold (0.51 log units) below what was measured; measured number above the stated range.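

In this assay, pyrrolidin-1-yl in place of diethylamino gave a gain on the core of compound 1 but no readable change on the core carrying oxolan-3-yl, with a 1.2-fold higher number from compound 3 to compound 4 (0.06 log units; within the scatter), and the two steps do not match: the same change on two cores in this assay, a 2.9-fold lower number (0.46 log units; beyond the scatter) from compound 1 to compound 2 and a 1.2-fold higher number (0.06 log units; within the scatter) from compound 3 to compound 4, 3.3-fold (0.52 log units) apart, beyond the scatter of two such steps Seen from the other side, oxolan-3-yl in place of methyl on the aromatic oxygen gave a 2.9-fold higher number from compound 2 to compound 4 (0.47 log units; beyond the scatter), which also fails to match its earlier step: the same change on two cores in this assay, a 1.1-fold lower number (0.05 log units; within the scatter) from compound 1 to compound 3 and a 2.9-fold higher number (0.47 log units; beyond the scatter) from compound 2 to compound 4, 3.3-fold (0.52 log units) apart, beyond the scatter of two such steps This shows that, among these four compounds, a step measured on one core could not simply be carried to the other, even though compound 1 and compound 3 themselves could not be told apart; it does not show why, or whether other pairs of groups would behave the same way.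

Going by these compounds, it remains open whether another amine on the chain, such as piperidin-1-yl or morpholin-4-yl, would follow compound 2 or compound 4. On these data alone, it also remains open how a longer chain on the aromatic oxygen, such as 2-methoxyethyl, would combine with either amine.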